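This account rests on a few compounds, and the source may have more. Where it says the series, first, only, none or still open, it means among the compounds named here.

Measured compounds:
compound 1 `CC(C)=CC(=O)Nc1c(C(O)(C(F)(F)F)C(F)(F)F)ccc2ccccc12` — 96% in a functional assay (Sus scrofa) with sulfonylurea receptors; K-ATP channels (Homo sapiens) as the target; on this read-out lower numbers stand for smaller maximal responses and higher numbers for larger maximal responses
compound 2 `O=C(Nc1c(C(O)(C(F)(F)F)C(F)(F)F)ccc2ccccc12)C1CCC1` — 97% in this assay

Compound 1 stands lowest of the two numbers in this assay, yet its nearest neighbour, compound 2, lies only a number 1 percentage points higher from compound 1 to compound 2 (within the scatter) away, so the two are not separable. Compound 3 `O=C(Nc1c(C(O)(C(F)(F)F)C(F)(F)F)ccc2ccccc12)c1cccc([N+](=O)[O-])c1` differs from compound 1 by 3-nitrophenyl in place of 2-methylprop-1-en-1-yl on a carbonyl carbon. Among the measured compounds shown here, the one measured step, the exchange of groups on the carbonyl carbon whose other neighbour is the amide-type nitrogen that leads from compound 1 to compound 2, stayed within the scatter, and both measured compounds reach a maximal response close to the control. For the measured compounds named here, no measured step introduces an aromatic ring at this place, so the bearing of that single step is limited. The expected change for compound 3 in this assay is therefore a number 3 percentage points lower from compound 1 to compound 3 (within the scatter), none beyond the scatter. Compound 3 is estimated at 93%, between 72% and 105%.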

Compound 3, largest response reached (reported as efficacy), in percent of the reference or control that the assay uses: 99%
Compound 3: middle estimate off by 6 percentage points, on the low side; measured number inside the range.
By their numbers in this assay, from the lowest: compounds 1, 2 and 3 (each within the scatter of the next).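

In this assay, 3-nitrophenyl on the carbonyl carbon whose other neighbour is the amide-type nitrogen gave a number 3 percentage points higher from compound 1 to compound 3 (within the scatter) in place of 2-methylprop-1-en-1-yl, and a number 2 percentage points higher from compound 2 to compound 3 (within the scatter) in place of cyclobutyl. The earlier compounds shown here had covered only groups without an aromatic ring at this place, and the three compounds now cannot be told apart, so a six-membered aromatic ring carrying a nitro group is as compatible with a full response here as the two smaller groups. Nothing available explains this sameness.

The compounds shown leave open whether any group at this place lowers the maximal response, since none here does. A plain phenyl, an amine or a carboxylic acid in place of the nitro group, or a longer alkyl chain on the carbonyl carbon, could test where that tolerance ends.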